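Bromo in place of ethyl on a shared core

A few compounds are considered here, and "the series" means these few. Any claim that something is new, unique, unknown or untested is made for them only; others in the source may bear on it.

Compound 2 `CCc1cccc(NC(=O)N[C@@H](C)c2ccccc2)c1` is the starting point. In an ADME assay on the whole organism with Oryza sativa as the target, tested at 1 uM (on this read-out lower numbers stand for a stronger effect and higher numbers for a weaker effect at the one concentration tested), compound 2 gives 94%. Compound 1 `CCc1cccc(NC(=O)N[C@H](C)c2ccccc2)c1` gives 71%, and the change a number 23 percentage points higher from compound 1 to compound 2 (beyond the scatter) rests only on (the fact that compounds 1 and 2 differ only in the configuration as drawn). Compound 3 `COc1ccccc1NC(=O)N[C@@H](C)c1ccccc1` gives 99%, a number within the scatter of compound 2, so those two cannot be ordered. Compound 2 therefore stands second highest of the three numbers, close to compound 3 and well apart from compound 1, whose lower number means a stronger effect.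

Compound 4 `C[C@H](NC(=O)Nc1cccc(Br)c1)c1ccccc1` differs from compound 2 by bromo in place of ethyl on an aromatic carbon. Within the data shown here, none of the measured steps exchanges one group on the aromatic ring for another; the single measured step concerns configuration, which compounds 2 and 4 share. There is thus no measured ground for a step beyond the scatter in this assay. Compound 4 is expected to give 90%, with a range from 70% to 100%. The estimated step of a number 4 percentage points lower from compound 2 to compound 4 (within the scatter) is expected to lie within the scatter.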

Compound 4, a percentage reported as activity, at one concentration (the size of the read-out at that concentration, not a potency): 100%
Compound 4: middle estimate off by 10 percentage points, on the low side; low and high end bracket the measured number.
By their numbers in this assay, from the lowest: compound 1; then compounds 2, 3 and 4 (each within the scatter of the next).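

In this assay, among these compounds, bromo in place of ethyl is the first exchange of one ring group for another on the shared core, and it gives a number 6 percentage points higher from compound 2 to compound 4 (within the scatter). At this place, on an aromatic carbon and meta to a large group, a single bromine can therefore stand in for the two carbons of ethyl with no change that can be told from the scatter. Nothing on hand bears on why these two groups read alike.

As far as these compounds go, it remains open whether an amine, a carboxylic acid or a longer chain at this place would move the number beyond the scatter. From the compounds shown here alone, it is also open whether the configuration drawn in compound 1, which carries the lower number among the ethyl pair, would give a similar step with bromo on the ring.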